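The source may report more compounds than this note shows. Statements on the series, on what has been measured and on what is new or still open speak of the compounds shown alone.

Compound 1, `CN(C)c1ccc(C2CC(c3ccc(-n4ccnc4)cc3)=NN2)cc1`: 0.1%
Compound 2, `CC(=O)N1N=C(c2ccc(-n3ccnc3)cc2)CC1c1ccc(N(C)C)cc1`: -2.1%
Compound 3, `CN(C)c1ccc(C2CC(c3ccc(-n4ccnc4)cc3)=NN2C(=O)CCCl)cc1`: -2.5%

These three compounds share one core and were all tested in a functional assay on NCI-H1975 cells (Homo sapiens) for inhibition, read by sulforhodamine B assay, tested at 10 uM (a lower number here means less inhibition, a higher number more inhibition at the concentration tested (going by the name of the read-out)), where all three sit close to zero. Compound 3 has the lowest of the three numbers, but a number 2.6 percentage points lower from compound 1 to compound 3 (within the scatter) and a number 0.4 percentage points lower from compound 2 to compound 3 (within the scatter) both lie within the scatter, so the three cannot be told apart on these numbers.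

Compound 4, `C=C(C)C(=O)N1N=C(c2ccc(-n3ccnc3)cc2)CC1c1ccc(N(C)C)cc1`, differs from compound 3 by 1-methylethenyl in place of 2-chloroethyl on a carbonyl carbon. For the measured compounds named here, the steps that bear on this change are a number 2.2 percentage points lower from compound 1 to compound 2 (within the scatter) and a number 0.4 percentage points lower from compound 2 to compound 3 (within the scatter), both within the scatter, and no measured step exchanges one group for another on this carbonyl carbon. Nothing here points to a move beyond the scatter in this assay. Compound 4 is therefore expected to give about -1%, likely between -12% and 10%, an estimated step of a number 1.5 percentage points higher from compound 3 to compound 4 (within the scatter) that should stay within the scatter.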

Compound 4, a percentage reported as inhibition, at one concentration (the size of the read-out at that concentration, not a potency): -3.7%
Compound 4: the middle estimate sits 2.7 percentage points above what was measured; low and high end bracket the measured number.
By their numbers in this assay, from the lowest: compounds 4, 3, 2 and 1 (each within the scatter of the next).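

In this assay the exchange of 2-chloroethyl for 1-methylethenyl on this carbonyl carbon gives a number 1.2 percentage points lower from compound 3 to compound 4 (within the scatter) and so adds a direct swap of one group for another at this position. Methyl replaced by 1-methylethenyl gives a number 1.6 percentage points lower from compound 2 to compound 4 (within the scatter) while (1-methylethenyl)carbonyl in place of hydrogen on the ring nitrogen gives a number 3.8 percentage points lower from compound 1 to compound 4 (within the scatter) and thus the double bond does not set compound 4 apart from the other three. No measurement here offers an explanation for this result.

On these data alone, whether an amine, a carboxylic acid or a longer chain on this carbonyl carbon would lift the number clear of zero stays open. So does whether any change elsewhere on the shared core would.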